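The source may hold more compounds than are shown below. What is called first, only, known or untested is meant among the compounds shown, and "the series" means these compounds.

Within the data shown here, compound 3 `C=CCn1c(=O)/c(=C\c2cc(Br)ccc2F)[nH]c(=O)/c1=C\c1ccccc1OC` is the weakest-looking entry among the numbers so far: in a functional assay on MCF7 cells (Homo sapiens) for cytotoxicity, read by CCK-8 assay, with a stated time of 72 h (on this read-out lower numbers stand for stronger inhibition and higher numbers for weaker inhibition), compound 3 gives 28100 nM, whereas compound 1 `C=CCn1c(=O)/c(=C\c2cccc(Cl)c2)[nH]c(=O)/c1=C\c1ccccc1OC` gives 5200 nM, and compound 2 `C=CCn1c(=O)/c(=C\c2ccc(Cl)c(Cl)c2)[nH]c(=O)/c1=C\c1ccccc1OC` is reported as "not active" (no number reported) without a number. Compound 4 `C=CCn1c(=O)/c(=C\c2ccccc2OC)[nH]c(=O)/c1=C\c1ccccc1OC` differs from compound 3 in one place: 2-methoxyphenyl in place of 5-bromo-2-fluorophenyl on a double-bonded chain carbon bound to an aromatic carbon. Among the measured compounds shown here, the only measured step at this place is a 5.4-fold higher number from compound 1 to compound 3 (0.73 log units; beyond the scatter), which shows that exchanging the aryl group there shifts the result modestly. For the measured compounds named here, no measured compound carries 2-methoxyphenyl at this place, so the direction cannot be read from the data. The step is therefore expected to be a 2.3-fold lower number from compound 3 to compound 4 (0.37 log units; beyond the scatter), and the estimate for compound 4 in this assay is 12000 nM, within a range of 3000 nM to 50000 nM.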

Compound 4, half-maximal inhibitory concentration: 41100 nM
For compound 4 the middle estimate is 3.4-fold (0.53 log units) below the measured one, and the stated range covers the measured number.
By their numbers in this assay, from the lowest: compound 1; then compounds 3 and 4 (each within the scatter of the next).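

Placing 2-methoxyphenyl where compound 3 carries 5-bromo-2-fluorophenyl gives a 1.5-fold higher number from compound 3 to compound 4 (0.17 log units; within the scatter) in this assay, so these two quite different aryl groups cannot be told apart on this read-out. The change from 3-chlorophenyl is larger, a 7.9-fold higher number from compound 1 to compound 4 (0.90 log units; beyond the scatter), which leaves compound 1 clearly separated from both compound 3 and compound 4. No supporting evidence is available to explain this pattern. The compounds shown all carry an aryl group at this place. They leave open how an amine or a carboxylic acid on that ring would read out here.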